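Replacing a Vinyl Amide with a Chloropyridine Amide

The source may hold more compounds than are shown below. What is called first, only, known or untested is meant among the compounds shown, and "the series" means these compounds.

Measured compounds:
compound 1 `C=CC(=O)Nc1cccc(-c2nc3ccccc3s2)c1`: > 25000 nM
compound 2 `O=C(Nc1cccc(-c2nc3ccccc3s2)c1)c1cccnc1Cl`: > 25000 nM
compound 3 `O=C(Nc1cccc(-c2nc3ccccc3s2)c1)c1ccc(Cl)nc1Cl`: > 25000 nM

The three compounds share one core and differ only in the group on the carbonyl carbon of the amide. In an ADME assay on HEK293 cells (Homo sapiens) for inhibition, with a stated time of 72 h (a higher number here means that more compound is needed for the effect, a lower number that less compound is needed), compound 1 gives > 25000 nM. This value is a limit of the assay, not a measured number. Compound 2 sits at a limit too. Compound 3 likewise sits at a limit. All three values sit at the limit of > 25000 nM in this assay, at which 3 of the 3 values shown sit, so compound 1 cannot be placed above or below the others; it simply stands at the same limit as they do.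

Compound 4 `O=C(Nc1cccc(-c2nc3ccccc3s2)c1)c1ccnc(Cl)c1` differs from compound 1 by 2-chloropyridin-4-yl in place of vinyl on a carbonyl carbon. Within the data shown here, the steps that bear on this change are a step that the two limits leave unreadable from compound 1 to compound 2 and a step that the two limits leave unreadable from compound 1 to compound 3, both of which put a chlorinated pyridine in place of the vinyl group and both of which remain unreadable, since start and end sit at the limit. No direction or size of a step can therefore be expected in this assay beyond what the limit allows.

Compound 4 is accordingly expected to give 30000 nM, with a range from 10000 nM to 100000 nM. The step that the limit leaves unreadable from compound 1 to compound 4 that this estimate means is expected to be unreadable as well.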

Compound 4, half-maximal effective concentration: > 25000 nM
Compound 4: only a limit was reported (the forecaster's own chance of this, stated with the estimate: 85%); the middle value lies beyond the limit too.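

In this assay compound 4 gives > 25000 nM, which is a limit and not a number. The steps linking compound 4 with compound 1, compound 2 and compound 3 cannot be read, because all four values stand at the same point: the limit of > 25000 nM in this assay, at which 4 of the 4 values shown sit.

The compounds shown leave open whether any of these groups on the carbonyl carbon changes the concentration needed for the effect.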